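The source may hold more compounds than are shown below. What is called first, only, known or untested is meant among the compounds shown, and "the series" means these compounds.

Measured compounds:
Compound 1 `CC(C)(C)c1cc(NC(=O)Nc2ccc(-c3cn4cccc(Cl)c4n3)cc2)no1`: 353 nM
Compound 2 `CC(C)(C)c1cc(NC(=O)Nc2ccc(-c3cn4cccc(C(F)(F)F)c4n3)cc2)no1`: a limit, > 900 nM
Compound 3 `Cc1ccn2cc(-c3ccc(NC(=O)Nc4cc(C(C)(C)C)on4)cc3)nc2c1`: 0.79 nM

In a functional assay on MV4-11 cells (Homo sapiens) for cytotoxicity, read by MTT assay, with a stated time of 72 h (on this read-out higher numbers stand for weaker inhibition and lower numbers for stronger inhibition), compound 3 stands at the lowest of the two numbers, with compound 1 giving 353 nM, a far higher number. For compound 2 this assay reports only a limit, > 900 nM. Compound 4 `CC(=O)Oc1ccn2cc(-c3ccc(NC(=O)Nc4cc(C(C)(C)C)on4)cc3)nc2c1` differs from compound 3 by acetoxy in place of methyl on an aromatic carbon. Going by the values given here, the only measured step, an at least 2.5-fold higher number from compound 1 to compound 2 (0.40 log units; beyond the scatter), is also a swap of one small group for another on the shared fused ring and moved the number upward, though it sits at a different position and involves different groups. Among the compounds with values here, no measured step swaps methyl for acetoxy. A modest move toward a higher number is therefore expected, a 5.1-fold higher number from compound 3 to compound 4 (0.70 log units; beyond the scatter). Compound 4 is estimated at 4 nM in this assay, with a range from 0.8 nM to 30 nM.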

Compound 4, half-maximal inhibitory concentration: 29.4 nM
Compound 4: the middle estimate sits 7.4-fold (0.87 log units) below what was measured; the range from low to high includes it.
By their numbers in this assay, from the lowest: compound 3; then compound 4; then compound 1. At a limit, above all of these: compound 2.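

In this assay the position opposite the ring nitrogen proves sensitive: acetoxy in place of methyl gives a 37-fold higher number from compound 3 to compound 4 (1.57 log units; beyond the scatter), the first step measured at this position. Acetoxy brings more heavy atoms and hydrogen-bond acceptors than methyl, and this single step changes both together, so neither can be singled out. No measurement shown here accounts for the size of this step. On these data alone, whether a methoxy, a hydroxy or an amine at this position would stay closer to compound 3 remains open.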